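From trifluoromethoxy to ethoxy: a step expected within scatter

The compounds below may be only part of what the source reports. "The series", "measured", "known", "first", "only" and "open" are said of these compounds alone.

Going by the values given here, compound 2 `O=C(NNc1nncc2ccccc12)C1CC1c1ccc(OC(F)(F)F)cc1` is one of two compounds measured so far in a functional assay on PC-3 cells (Homo sapiens) for inhibition, read by MTT assay, with a stated time of 72 h; on this read-out lower numbers stand for stronger inhibition and higher numbers for weaker inhibition. In this assay compound 2 gives 92000 nM, the highest of the two numbers, while compound 1 `COc1ccc(C2CC2C(=O)NNc2nncc3ccccc23)cc1` gives 64000 nM; the gap between them is within the usual scatter. Among the compounds with values here, the only measured step, a 1.4-fold higher number from compound 1 to compound 2 (0.16 log units; within the scatter), thus shows no effect beyond the scatter.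

Compound 3 `CCOc1ccc(C2CC2C(=O)NNc2nncc3ccccc23)cc1` has not yet been measured. It differs from compound 2 by ethyl in place of trifluoromethyl on an oxygen on an aromatic ring. The step from compound 1 to compound 2 is the one that bears on this change: it exchanged methyl for trifluoromethyl at the same oxygen and moved the number only within the scatter. An ethyl at that oxygen is closer in kind to the methyl of compound 1 than to the trifluoromethyl of compound 2, so a step of no more than the scatter, if anything towards a lower number, is expected in this assay. The estimate for compound 3 in this assay is 70000 nM, with a range from 30000 nM to 160000 nM. The expected step from compound 2 to compound 3 is a 1.3-fold lower number from compound 2 to compound 3 (0.12 log units; within the scatter), not beyond the scatter.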

Compound 3, half-maximal inhibitory concentration: 94000 nM
Beside the measured number, compound 3's estimate is 1.3-fold (0.13 log units) below it; low and high end bracket the measured number.
By their numbers in this assay, from the lowest: compounds 1, 2 and 3 (each within the scatter of the next).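

In this assay, putting ethyl in place of trifluoromethyl on an oxygen on an aromatic ring gives a 1.0-fold higher number from compound 2 to compound 3 (0.01 log units; within the scatter) and so stays within the scatter, and adding methyl on a saturated chain carbon bound to that oxygen gives a 1.5-fold higher number from compound 1 to compound 3 (0.17 log units; within the scatter) and also stays within the scatter. Where the earlier compounds offered only the comparison of methyl with trifluoromethyl, this oxygen now carries three different groups, and methyl, ethyl and trifluoromethyl cannot be told apart in this read-out, so neither extending methyl to ethyl nor replacing trifluoromethyl with ethyl has a visible effect here. No measured evidence is available to explain this result.

On these data alone, whether the same holds for a longer chain on this oxygen, such as propyl or butyl, or for a group of another kind carrying an amine or a carboxylic acid, remains open. All three compounds also share the same core, so they leave open whether a change elsewhere on that core would move the number beyond the scatter.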